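Enantiomer swap at the ring stereocentre of compound 2

The source may report more compounds than this note shows. Statements on the series, on what has been measured and on what is new or still open speak of the compounds shown alone.

Within the data shown here, compound 2 `CC(C)C[C@H]1C(=O)N=C(N)N1C(=O)OCc1ccccc1` is the only member of the pair with a number in a functional assay on the whole organism with Mus musculus as the target, with a stated time of 0.5 h (a higher number here means that more compound is needed for the effect, a lower number that less compound is needed), where compound 2 gives 92.8 mg/kg. Compound 1 `CC(C)C[C@@H]1N=C(N)NC1=O`, which lacks the benzyl carbamate on the ring nitrogen, gives > 300 mg/kg in this assay, a limit rather than a number. Compound 1 therefore sits at the limit of > 300 mg/kg in this assay, at which 1 of the 2 values shown sits. Among the measured compounds shown here, with only one numeric value, no measured step between two compounds exists in this assay, and no direction can be read from the data.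

Compound 3 `CC(C)C[C@@H]1C(=O)N=C(N)N1C(=O)OCc1ccccc1` is the next compound; it differs from compound 2 as follows: the two compounds have the same atoms and bonds and differ only in configuration as drawn: 1 of 1 stereo elements differ; a stereocentre at a saturated ring carbon is drawn S in compound 2 and R in compound 3. The change of configuration at the saturated ring carbon leaves every atom and bond in place.

No shown step tells how this assay responds to a change of configuration at this centre. The expectation is that compound 3 behaves within a step of a 1.7-fold higher number from compound 2 to compound 3 (0.24 log units; within the scatter), most likely no better than compound 2 and possibly weaker, with a real chance that only a limit is returned. The estimate for compound 3 in this assay is 160 mg/kg, with a range from 60 mg/kg to 300 mg/kg.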

Compound 3, dose for half-maximal effect: 547 mg/kg
Compound 3: the middle estimate sits 3.4-fold (0.53 log units) below what was measured, outside the stated range (above it).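

Among these compounds, the first measured step in this assay is a change of configuration alone at the saturated ring carbon, and it gives a 5.9-fold higher number from compound 2 to compound 3 (0.77 log units; beyond the scatter) with the form drawn S in compound 2 needing less compound. This step lies beyond the usual scatter, and no atom or bond changes along it, so the ring stereocentre is shown to count in this assay for this pair. The gap can be assigned to the configuration at this centre alone because of the following: the fact that compounds 2 and 3 differ only in the configuration as drawn.

Among the compounds shown here, compound 1 gives > 300 mg/kg in this assay, which is a limit and not a number, and no step to it can be read. Still open, from the compounds shown here alone, is whether an acetyl group or a methyl carbamate on the ring nitrogen, in place of the benzyl carbamate, would keep the same gap between the two configurations, and one pair cannot show whether the preference for the form drawn S extends beyond compound 2 and compound 3.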